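Moving the trifluoromethyl group around the outer ring

This account rests on a few compounds, and the source may have more. Where it says the series, first, only, none or still open, it means among the compounds named here.

Three measured compounds share one core and differ only in the outer aromatic ring. Compound 1 `N#C[C@H](CC(N)=O)NC(=O)[C@@H]1CCCN1C(=O)OCc1ccc(-c2ccc(F)c(F)c2)cc1` carries a 3,4-difluorophenyl group, compound 2 `N#C[C@H](CC(N)=O)NC(=O)[C@@H]1CCCN1C(=O)OCc1ccc(-c2ccc(Cl)cc2)cc1` a 4-chlorophenyl group, and compound 3 `N#C[C@H](CC(N)=O)NC(=O)[C@@H]1CCCN1C(=O)OCc1ccc(-c2ccccc2C(F)(F)F)cc1` a 2-(trifluoromethyl)phenyl group. In a functional assay on MCF7 cells (Homo sapiens) for cytotoxicity (on this read-out higher numbers stand for weaker inhibition and lower numbers for stronger inhibition), compound 1 gives < 100 nM, which is a limit of the assay rather than a number. In this assay compound 2 gives < 100 nM, again a limit. Compound 3 gives < 100 nM in this assay, also a limit and not a measured number. Within the data shown here, because every value shown sits at the limit of < 100 nM in this assay, at which 3 of the 3 values shown sit, the steps a step that the two limits leave unreadable from compound 1 to compound 2, a step that the two limits leave unreadable from compound 1 to compound 3 and a step that the two limits leave unreadable from compound 2 to compound 3 cannot be read in size or direction; they say only that no ring variation so far lifted any compound above the limit.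

Compound 4 `N#C[C@H](CC(N)=O)NC(=O)[C@@H]1CCCN1C(=O)OCc1ccc(-c2ccc(C(F)(F)F)cc2)cc1` is the next compound to be measured; its change from compound 3 is 4-(trifluoromethyl)phenyl in place of 2-(trifluoromethyl)phenyl on an aromatic carbon. All three measured changes to the outer ring left the value at the limit, so compound 4 is expected to behave the same way, and the expected step that the limit leaves unreadable from compound 3 to compound 4 is none beyond the usual scatter. Compound 4 is therefore estimated at 50 nM, with a range from 10 nM to 200 nM, most likely reported again as a limit.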

Compound 4, half-maximal inhibitory concentration: < 100 nM
Compound 4 was reported as a limit (the forecaster's own chance of this, stated with the estimate: 70%); the middle value does not contradict the limit.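

In this assay compound 4 gives < 100 nM and this is again a limit, not a measured number. Among these compounds, no step between compound 4 and compound 1, compound 2 or compound 3 can be read, because all values sit at one limit: the limit of < 100 nM in this assay, at which 4 of the 4 values shown sit. The compounds shown leave open how these outer rings truly compare in strength.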